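A few compounds are considered here, and "the series" means these few. Any claim that something is new, unique, unknown or untested is made for them only; others in the source may bear on it.

Compound 3 `COc1cccc(CNCCCNc2ccnc3cc(CC4CCCCC4)ccc23)c1O` stands lowest of the three compounds measured in a physicochemical assay for solubility, with a stated time of 18 h, at pH 7.4 (a higher number here means a more soluble compound, a lower number a less soluble compound), where compound 3 gives 4200 nM. Compound 1 `COc1ccc(Oc2ccc3c(NCCCNCc4cccc(OC)c4O)ccnc3c2)cc1` gives 14500 nM and compound 2 `COc1ccccc1Oc1ccc2c(NCCCNCc3cccc(OC)c3O)ccnc2c1` gives 14500 nM; the step of no change at the digits printed from compound 1 to compound 2 (within the scatter) shows that putting 2-methoxyphenyl in place of 4-methoxyphenyl on the oxygen made no difference, while a 3.5-fold lower number from compound 1 to compound 3 (0.54 log units; beyond the scatter) and a 3.5-fold lower number from compound 2 to compound 3 (0.54 log units; beyond the scatter) show that replacing either methoxyphenoxy group with cyclohexylmethyl lowered solubility modestly. Compound 4 `COc1cccc(CNCCCNc2ccnc3cc(-c4cccc5ccccc45)ccc23)c1O` differs from compound 3 by naphthalen-1-yl in place of cyclohexylmethyl on an aromatic carbon. Going by the values given here, no measured step covers this exchange of one ring group for another on the same carbon, so the expectation rests on compound 3 alone. For compound 4, a small further drop in this assay is expected, a 1.7-fold lower number from compound 3 to compound 4 (0.23 log units; within the scatter), giving an estimated 2500 nM within 800 nM to 8000 nM.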

Compound 4, solubility: 32000 nM
Beside the measured number, compound 4's estimate is 13-fold (1.11 log units) below it; the whole stated range lies below it.
By their numbers in this assay, from the lowest: compound 3; then compounds 1 and 2 (each within the scatter of the next); then compound 4.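

In this assay, the exchange at this aromatic carbon gives a 7.6-fold higher number from compound 3 to compound 4 (0.88 log units; beyond the scatter), so a larger all-carbon group need not give a lower number here. Compound 4 also stands apart from the two methoxyphenoxy compounds, with a 2.2-fold higher number from compound 2 to compound 4 (0.34 log units; beyond the scatter) and a 2.2-fold higher number from compound 1 to compound 4 (0.34 log units; beyond the scatter), which makes it the highest of the four. On these data alone, whether naphthalen-2-yl, or a ring carrying an amine or a carboxylic acid, would follow compound 4 at this carbon remains open. Nothing measured here explains the rise.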